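The compounds below may be only part of what the source reports. "The series", "measured", "known", "first", "only" and "open" are said of these compounds alone.

Measured compounds:
- compound 1, `CCCCC(CCO)n1cnc2cncnc21`: > 50000 nM
- compound 2, `CCCCCC(CCO)n1cnc2cncnc21`: > 50000 nM
- compound 3, `CCCCCCCC(CCO)n1cnc2c(Cl)nc(F)nc21`: 26100 nM

In a functional assay on SW480 cells (Homo sapiens) for antiproliferative activity, read by MTT assay, with a stated time of 48 h (a lower number here means a stronger inhibitor, a higher number a weaker inhibitor), compound 1 gives only a limit, > 50000 nM. Compound 2 likewise gives only a limit in this assay, > 50000 nM. The change between them is methyl in place of hydrogen on a saturated chain carbon, five bonds along the chain from an aromatic nitrogen, and its step, a step that the two limits leave unreadable from compound 1 to compound 2, cannot be read because the limit of > 50000 nM in this assay, at which 2 of the 3 values shown sit, holds both values. Compound 3, on a different core, gives 26100 nM in this assay; the difference between the two cores is not broken down here.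

Compound 4, `CCCCCCCCC(CCO)n1cnc2c(Cl)nc(F)nc21`, is not yet measured. It differs from compound 3 by methyl in place of hydrogen on a saturated chain carbon, eight bonds along the chain from an aromatic nitrogen. This is the same kind of change as that from compound 1 to compound 2, but the place differs: there the methyl enters five bonds along the chain from an aromatic nitrogen, here eight bonds along the chain from an aromatic nitrogen. With the earlier step unreadable, no size for it is known; the expected step from compound 3 to compound 4 is taken as small, a 1.3-fold lower number from compound 3 to compound 4 (0.12 log units; within the scatter), resting on compound 3 at 26100 nM. Compound 4 is therefore estimated at 20000 nM, expected between 7000 nM and 60000 nM.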

Compound 4, half-maximal inhibitory concentration: 15000 nM
Compound 4: middle estimate off by 1.3-fold (0.12 log units), on the high side; low and high end bracket the measured number.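

In this assay, the added methyl on the core of compound 3 gives a 1.7-fold lower number from compound 3 to compound 4 (0.24 log units; within the scatter), so on this core the change cannot be told apart from repeat measurement. The same kind of change on the core of compound 1 cannot be read, because compound 1 and compound 2 each give only a limit: the limit of > 50000 nM in this assay, at which 2 of the 4 values shown sit. The series therefore shows no transfer between cores, neither that the step carries over nor that it fails to, and the methyl also sits at a different place on each core, five bonds along the chain from an aromatic nitrogen on one and eight bonds on the other.

Still open, going by these compounds, is whether any compound on the core of compound 1 gives a number rather than a limit. Also open, on these data alone, is how a longer chain, or an amine on the chain, would read on the core of compound 3.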